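Cyclobutyl for Chloro on the Amide Side Chain

The source may report more compounds than this note shows. Statements on the series, on what has been measured and on what is new or still open speak of the compounds shown alone.

Compound 1 `CC(=O)N[C@H]1[C@H]([C@@H](O)[C@H](O)CNC(=O)c2ccc(Cl)cc2)O[C@@](OCc2ccc3ccccc3c2)(C(=O)O)C[C@@H]1O`: 11600 nM
Compound 2 `O=C(CCl)N[C@H]1[C@H]([C@@H](O)[C@H](O)CNC(=O)c2ccc(Cl)cc2)O[C@@](OCc2cccc(F)c2F)(C(=O)O)C[C@@H]1O`: 2100 nM

In an in vitro assay on cells for binding affinity to myelin-associated glycoprotein (Mus musculus), read by surface plasmon resonance (a lower number here means tighter binding, a higher number weaker binding), compound 2 holds the lower of the two numbers, and the gap to compound 1 lies beyond the scatter. Compound 3 `O=C(CC1CCC1)N[C@H]1[C@H]([C@@H](O)[C@H](O)CNC(=O)c2ccc(Cl)cc2)O[C@@](OCc2cccc(F)c2F)(C(=O)O)C[C@@H]1O` differs from compound 2 by cyclobutyl in place of chloro on a saturated chain carbon bound to a carbonyl carbon. Among the compounds with values here, no measured pair shows this change, so the size of the step is uncertain; a small step toward weaker binding, close to the scatter, is expected, and the expected step is a 1.9-fold higher number from compound 2 to compound 3 (0.28 log units; within the scatter). Compound 3 is therefore estimated at 4000 nM. For compound 3 the expected range runs from 1500 nM to 12000 nM.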

Compound 3, dissociation constant: 5800 nM
Beside the measured number, compound 3's estimate is 1.5-fold (0.16 log units) below it, within the range that was stated.
By their numbers in this assay, from the lowest: compound 2; then compounds 3 and 1 (each within the scatter of the next).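

In this assay, within the data shown here, the change gives a 2.8-fold higher number from compound 2 to compound 3 (0.44 log units; beyond the scatter) and so provides the first reading at a single place: at this saturated chain carbon bound to a carbonyl carbon, cyclobutyl in place of chloro weakens binding beyond the scatter. The position is therefore sensitive to the group it carries. No measurement shown accounts for this step.

Compound 1 differs from both other compounds in more than one place, so it cannot isolate this change. As far as these compounds go, whether an open-chain butyl group or an amine at this carbon would bind more like chloro or cyclobutyl remains open.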